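The source may hold more compounds than are shown below. What is called first, only, known or untested is meant among the compounds shown, and "the series" means these compounds.

Measured compounds:
- compound 1 `CCCn1c(=O)[nH]c2nc(-c3ccc(S(=O)(=O)N4CCN(c5ccc(F)cc5)CC4)cc3)[nH]c2c1=O`: in an assay on CHO cells for displacement of a labelled ligand from adenosine receptor A1 (Homo sapiens), read by scintillation counting, with a stated time of 90 min, in the presence of a further agent that is not named here (on this read-out higher numbers stand for weaker inhibition and lower numbers for stronger inhibition), compound 1 reaches only a limit of the assay, > 1000 nM.
- compound 2 `CCCn1c(=O)[nH]c2nc(-c3ccc(S(=O)(=O)N4CCN(c5ccccc5Br)CC4)cc3)[nH]c2c1=O`: in this assay compound 2 likewise sits at a limit, > 1000 nM.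
- compound 3 `CCCn1c(=O)[nH]c2nc(-c3ccc(S(=O)(=O)N4CCN(Cc5ccc(Br)c(F)c5)CC4)cc3)[nH]c2c1=O`: in this assay compound 3 gives 326 nM.

Compound 1 thus stands at a limit rather than at a number, and it cannot be ranked against compound 2: a step that the two limits leave unreadable from compound 1 to compound 2. Against compound 3 the step reads only as a lower bound, an at least 3.0-fold lower number from compound 1 to compound 3 (0.48 log units; beyond the scatter), as does an at least 3.0-fold lower number from compound 2 to compound 3 (0.48 log units; beyond the scatter). For the measured compounds named here, the two values at the limit belong to compound 1 with 4-fluorophenyl and compound 2 with 2-bromophenyl on an amine nitrogen in a ring; the single read number belongs to compound 3 with 4-bromo-3-fluorobenzyl there. Going by the values given here, the sole evidence on the measured steps is the limit of > 1000 nM in this assay, at which 2 of the 3 values shown sit.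

Compound 4 `CCCn1c(=O)[nH]c2nc(-c3ccc(S(=O)(=O)N4CCN(c5ccccc5)CC4)cc3)[nH]c2c1=O` differs from compound 1 by hydrogen in place of fluoro on an aromatic carbon. No measured step bears on this change itself; the shown steps concern the whole group on an amine nitrogen in a ring, and the step between the two phenyl-type groups is unreadable. Compound 4 keeps phenyl on an amine nitrogen in a ring, like compound 1 and compound 2, so no step beyond the scatter is expected. Compound 4 is estimated at 2000 nM (range 600 nM to 8000 nM) in this assay, most probably again a limit. The expected step that the limit leaves unreadable from compound 1 to compound 4 is none beyond the scatter.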

Compound 4, inhibition constant: 364 nM
For compound 4 the middle estimate is 5.5-fold (0.74 log units) above the measured one; the measured number lies below the stated range.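

Hydrogen in place of fluoro on an aromatic carbon, para to a large group, gives the first readable step for this change in this assay: an at least 2.7-fold lower number from compound 1 to compound 4 (0.43 log units; beyond the scatter), so the plain phenyl group, unlike the 4-fluorophenyl group, gives a read number. Hydrogen in place of bromo gives a bound of the same kind, an at least 2.7-fold lower number from compound 2 to compound 4 (0.43 log units; beyond the scatter), so in the compounds shown both halogen-bearing phenyl groups sit at the limit and the plain phenyl group does not. The plain phenyl and 4-bromo-3-fluorobenzyl groups on the amine nitrogen are not separated, a 1.1-fold higher number from compound 3 to compound 4 (0.05 log units; within the scatter), so a read number in this series does not depend on the benzyl group.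

Going by these compounds, the true size of the two steps from the halogen-bearing phenyl compounds remains open, and they stand only as bounds: the limit of > 1000 nM in this assay, at which 2 of the 4 values shown sit. On these data alone, it also remains open whether the step follows the halogen itself or extends to other groups on the phenyl ring, such as methyl, methoxy or nitrile, and how an unsubstituted benzyl group would compare with the plain phenyl group.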